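Swapping the amide substituent on a macrolide ether chain

The compounds below may be only part of what the source reports. "The series", "measured", "known", "first", "only" and "open" are said of these compounds alone.

Measured so far:
compound 1 `CC[C@H]1OC(=O)[C@H](C)[C@@H](O[C@H]2C[C@@](C)(OC)[C@@H](O)[C@H](C)O2)[C@H](C)[C@@H](O[C@@H]2O[C@H](C)C[C@H](N(C)C)[C@H]2O)[C@](C)(O)C[C@@H](C)CN(C)[C@H](C)[C@@H](OCCCNC(=O)C2CCC2)[C@]1(C)O`: 3.5
compound 2 `CCCCCCCC(=O)NCCCO[C@@H]1[C@@H](C)N(C)C[C@H](C)C[C@@](C)(O)[C@H](O[C@@H]2O[C@H](C)C[C@H](N(C)C)[C@H]2O)[C@@H](C)[C@H](O[C@H]2C[C@@](C)(OC)[C@@H](O)[C@H](C)O2)[C@@H](C)C(=O)O[C@H](CC)[C@@]1(C)O`: 5.18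
compound 3 `CC[C@H]1OC(=O)[C@H](C)[C@@H](O[C@H]2C[C@@](C)(OC)[C@@H](O)[C@H](C)O2)[C@H](C)[C@@H](O[C@@H]2O[C@H](C)C[C@H](N(C)C)[C@H]2O)[C@](C)(O)C[C@@H](C)CN(C)[C@H](C)[C@@H](OCCCNC(=O)c2c(C)nn(C)c2Cl)[C@]1(C)O`: 3.01

In a physicochemical assay for lipophilicity, read by HPLC, measured as chromatographic lipophilicity, at pH 7.4 (a higher number here means a more lipophilic compound, a lower number a more polar compound), compound 3 holds the lowest of the three values; compound 1 sits closer, and compound 2 sits furthest away, as the steps of a number 0.49 log units lower from compound 1 to compound 3 (beyond the scatter) and a number 2.17 log units lower from compound 2 to compound 3 (beyond the scatter) show. Compound 4 `CC[C@H]1OC(=O)[C@H](C)[C@@H](O[C@H]2C[C@@](C)(OC)[C@@H](O)[C@H](C)O2)[C@H](C)[C@@H](O[C@@H]2O[C@H](C)C[C@H](N(C)C)[C@H]2O)[C@](C)(O)C[C@@H](C)CN(C)[C@H](C)[C@@H](OCCCNC(=O)COC)[C@]1(C)O` differs from compound 3 only on the carbonyl carbon: methoxymethyl in place of 5-chloro-1,3-dimethyl-1H-pyrazol-4-yl on a carbonyl carbon. Both measured steps concern the same position, and the large step from compound 2 onwards shows how strongly this assay responds to what sits there. Within the data shown here, no measured step covers methoxymethyl itself, so the expectation rests on the trend among the three groups. Compound 4 is expected to fall a modest step below compound 3, a number 0.51 log units lower from compound 3 to compound 4 (beyond the scatter), landing near 2.5, between 2 and 3.1.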

Compound 4, distribution coefficient: 2.58
The estimate for compound 4 lay 0.08 log units below the measured number; low and high end bracket the measured number.
By their numbers in this assay, from the lowest: compound 4; then compound 3; then compound 1; then compound 2.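

In this assay, methoxymethyl on the carbonyl carbon puts compound 4 lowest of the four, with steps to it from every other compound (a number 0.43 log units lower from compound 3 to compound 4 (beyond the scatter); a number 0.92 log units lower from compound 1 to compound 4 (beyond the scatter); a number 2.60 log units lower from compound 2 to compound 4 (beyond the scatter)). A group with no ring and 3 heavy atoms thus stands below the aromatic pyrazolyl group with 8, while heptyl, which also has no ring, stands highest, so the absence of a ring does not by itself set the number. Nothing available explains this order. Going by these compounds, whether an amine or a carboxylic acid on this carbonyl carbon would give a lower number stays open, as does how far a longer ether chain would move it.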